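This account rests on a few compounds, and the source may have more. Where it says the series, first, only, none or still open, it means among the compounds named here.

Working notes on the biaryl sulfonamide series in a functional assay on J774 cells (Mus musculus) for cytotoxicity, read by resazurin assay, with a stated time of 72 h; a higher number here means a weaker inhibitor, a lower number a stronger inhibitor. Going by the values given here, compound 2 `O=S(=O)(Nc1ccc(CO)c(CO)c1)c1ccc(-c2ccc(F)cc2)cc1` gives 1000 nM and stands as the highest of the two numbers so far. Among the compounds with values here, compound 3 `O=S(=O)(Nc1ccc(CO)c(CO)c1)c1ccc(-c2ccc(F)cc2F)cc1` gives 150 nM; the step of a 6.7-fold lower number from compound 2 to compound 3 (0.82 log units; beyond the scatter) is the only one-point change with a number at both ends. Compound 1 `O=S(=O)(Nc1cccc(CO)c1O)c1ccc(-c2ccc(Br)cc2)cc1` reaches only a limit, > 5000 nM, which is the limit of > 5000 nM in this assay, at which 1 of the 3 values shown sits, and not a measured number.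

Compound 4 `O=S(=O)(Nc1cccc(CO)c1)c1ccc(-c2ccc(F)cc2)cc1` differs from compound 2 by hydrogen in place of hydroxymethyl on an aromatic carbon, ortho to a hydroxymethyl group and para to a large group. Within the data shown here, no measured step removes a hydroxymethyl. The step from compound 2 to compound 3 changes a fluoro and does not speak to this change, and compound 1 carries a different substitution and gives only a limit. The expected step of a 1.5-fold higher number from compound 2 to compound 4 (0.18 log units; within the scatter) is therefore small, not clearly beyond the scatter, with wide uncertainty. Compound 4 is estimated at 1500 nM, in the range 400 nM to 6000 nM.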

Compound 4, half-maximal inhibitory concentration: 3500 nM
For compound 4 the middle estimate is 2.3-fold (0.37 log units) below the measured one; measured number inside the range.
By their numbers in this assay, from the lowest: compound 3; then compound 2; then compound 4. At a limit, above all of these: compound 1.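

In this assay, hydrogen in place of hydroxymethyl on an aromatic carbon, ortho to a hydroxymethyl group and para to a large group, gives a 3.5-fold higher number from compound 2 to compound 4 (0.54 log units; beyond the scatter). Compound 2 now has two one-point changes with a number at both ends, and they run in opposite directions: the added fluoro lowers the number, while losing this hydroxymethyl raises it. No measurement shown gives a cause for this step.

On these data alone, it remains open whether the step reflects the hydroxymethyl itself or would follow the loss of any group at this position; an amine, a carboxylic acid or a methoxy group there would help separate the two readings. As far as these compounds go, it is also open whether the added fluoro would lower the number in the same way with hydrogen at this position.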